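The source may report more compounds than this note shows. Statements on the series, on what has been measured and on what is new or still open speak of the compounds shown alone.

Measured in an ADME assay on NIH3T3 cells (Mus musculus) for cytotoxicity, with a stated time of 72 h; on this read-out lower numbers stand for stronger inhibition and higher numbers for weaker inhibition:
- compound 1 `OC[C@H]1O[C@@H](n2cnc3c(NCc4ccccc4F)ncnc32)[C@H](O)[C@@H]1O`: > 166000 nM (a limit)
- compound 2 `OC[C@H]1O[C@@H](n2cnc3c(NCc4cccc(F)c4)ncnc32)[C@H](O)[C@@H]1O`: 84000 nM
- compound 3 `OC[C@H]1O[C@@H](n2cnc3c(NCc4ccccc4Br)ncnc32)[C@H](O)[C@@H]1O`: > 166000 nM (a limit)

Compound 3 gives no number, only a limit, and it stands at the limit of > 166000 nM in this assay, at which 2 of the 3 values shown sit. Compound 4 `OC[C@H]1O[C@@H](n2cnc3c(NCc4cccc(Br)c4)ncnc32)[C@H](O)[C@@H]1O` has the same atoms joined differently, with 3-bromophenyl in place of 2-bromophenyl on a saturated chain carbon bound to a nitrogen on an aromatic ring.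

The closest guide is the matching change with fluoro in place of bromo, an at least 1.9-fold lower number from compound 1 to compound 2 (0.29 log units; that floor lies within the scatter). The step of an at least 1.9-fold higher number from compound 2 to compound 3 (0.29 log units; that floor lies within the scatter) points the same way, although it changes the halogen as well. From the compounds shown here alone, both are known only as floors, so their true sizes remain open. A move to a lower number in this assay is therefore expected, bringing compound 4 into the region of compound 2 at 84000 nM. Compound 4 may yet give only a limit, as compound 3 does. The expected step is an at least 1.8-fold lower number from compound 3 to compound 4 (0.26 log units; that floor lies within the scatter). Compound 4 is estimated at 90000 nM, with an expected range from 35000 nM to 220000 nM.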

Compound 4, half-maximal inhibitory concentration: > 166000 nM
Compound 4 gave a limit, no number (the forecaster's own chance of this, stated with the estimate: 40%); middle value at least 1.8-fold (0.26 log units) from the limit.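

In this assay compound 4 gives > 166000 nM, which is a limit and not a number, so 3-bromophenyl does not yield a measured value in the way 3-fluorophenyl does in compound 2. Bromo in place of fluoro on an aromatic carbon gives an at least 1.9-fold higher number from compound 2 to compound 4 (0.29 log units; that floor lies within the scatter), while the steps among compound 1, compound 3 and compound 4 cannot be read, as both ends of each are limits. The lower number expected from the fluoro pair therefore does not show up in the bromo pair, and compound 2 alone carries a number: the limit of > 166000 nM in this assay, at which 3 of the 4 values shown sit.

From the compounds shown here alone, how far compound 1, compound 3 and compound 4 lie beyond that limit stays unknown, so they cannot be ranked. Also open, going by these compounds, is what a chloro or a methoxy group in place of the bromo would give in this assay.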